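Benzyl ether variants on the shared core: toward compound 4

The compounds below may be only part of what the source reports. "The series", "measured", "known", "first", "only" and "open" are said of these compounds alone.

Measured so far in an assay on CHO cells for binding affinity to metabotropic glutamate receptor 2 (Rattus norvegicus); on this read-out lower numbers stand for stronger inhibition and higher numbers for weaker inhibition:
compound 1 `CO[C@@H]1C[C@@H]2[C@H]([C@]1(N)C(=O)O)[C@@]2(F)C(=O)O` gives 39.2 nM
compound 2 `N[C@]1(C(=O)O)[C@H]2[C@@H](C[C@H]1OCc1ccccc1)[C@]2(F)C(=O)O` gives 7.14 nM
compound 3 `N[C@]1(C(=O)O)[C@H]2[C@@H](C[C@H]1OCc1cccc(Cl)c1)[C@]2(F)C(=O)O` gives 3.28 nM

Compound 3 holds the lowest number of the three. Its nearest neighbour is compound 2, the step being a 2.2-fold lower number from compound 2 to compound 3 (0.34 log units; beyond the scatter); the furthest is compound 1, with a 12-fold lower number from compound 1 to compound 3 (1.08 log units; beyond the scatter). Both steps lie beyond the scatter, so compound 3 stands as the strongest binder among the measured set.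

Compound 4 `N[C@]1(C(=O)O)[C@H]2[C@@H](C[C@H]1OCc1cc(F)cc(F)c1)[C@]2(F)C(=O)O` differs from compound 3 in one place: 3,5-difluorophenyl in place of 3-chlorophenyl on a saturated chain carbon bound to an oxygen on a saturated carbon. Among the compounds with values here, two measured steps bear on this change. Adding a phenyl to the ether carbon, a 5.5-fold lower number from compound 1 to compound 2 (0.74 log units; beyond the scatter), was modest; adding a chloro to that aromatic ring, a 2.2-fold lower number from compound 2 to compound 3 (0.34 log units; beyond the scatter), was modest as well. The change to compound 4 keeps the aromatic ring and swaps one halogen for two smaller ones; nothing measured here tells how such a swap behaves on this core. The halogen-bearing ring in compound 3 and the halogen-free ring in compound 2 set the likely span, so compound 4 is expected to land near compound 3, with no step beyond the scatter in this assay.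

Compound 4 is expected to give 4 nM (1.5 nM to 10 nM). The estimated step for compound 4 is a 1.2-fold higher number from compound 3 to compound 4 (0.09 log units; within the scatter), expected to stay within the scatter.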

Compound 4, inhibition constant: 12.4 nM
For compound 4 the middle estimate is 3.1-fold (0.49 log units) below the measured one; measured number outside the range, above it.
By their numbers in this assay, from the lowest: compound 3; then compounds 2 and 4 (each within the scatter of the next); then compound 1.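

In this assay the ring on the ether carbon proves sensitive to which halogens it carries: a 3.8-fold higher number from compound 3 to compound 4 (0.58 log units; beyond the scatter) marks the swap to 3,5-difluorophenyl, so a halogen on this ring does not by itself keep the gain seen with 3-chlorophenyl. Set against the plain phenyl, the two fluorines leave the number within the scatter at a 1.7-fold higher number from compound 2 to compound 4 (0.24 log units; within the scatter) and the 3,5-difluorophenyl ether still holds a clear margin over the core of compound 1 with a 3.2-fold lower number from compound 1 to compound 4 (0.50 log units; beyond the scatter) as its step, so the benefit of the aromatic ring survives this substitution. No evidence is at hand that accounts for the difference between the 3-chlorophenyl and 3,5-difluorophenyl rings.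

The compounds shown do not separate the effect of replacing chlorine with fluorine from that of carrying a second halogen, and a 3-fluorophenyl or 3,5-dichlorophenyl ring would bear directly on that question. From the compounds shown here alone, how this position responds to a ring carrying something other than a halogen, such as a methoxy group or a nitrile, also remains open.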